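A few compounds are considered here, and "the series" means these few. Any claim that something is new, unique, unknown or untested is made for them only; others in the source may bear on it.

Series notes, measured in an ADME assay on the whole organism (strain Wistar) for pharmacokinetics, with Rattus norvegicus as the target, given by the intravenous route; on this read-out higher numbers stand for fast clearance and lower numbers for slow clearance:

- compound 1 `CC[C@@H](c1ccc(C(=O)O)c(Oc2cccc(Cl)c2)c1F)N1CCC[C@H](n2cc(C)c(=O)[nH]c2=O)C1`: "not determined" (no result reported)
- compound 2 `CC[C@H](c1ccc(C(=O)O)c(Oc2cccc(Cl)c2)c1OC)N1CCC[C@H](n2cc(C)c(=O)[nH]c2=O)C1`: 84 mL/min/kg
- compound 3 `CCC[C@@H](c1ccc(C(=O)O)c(Oc2cccc(Cl)c2)c1OC)N1CCC[C@H](n2cc(C)c(=O)[nH]c2=O)C1`: "not determined" (no result reported)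

Compound 2 is the only one of the three with a number in this assay, at 84 mL/min/kg. It therefore cannot be ranked against the others. Within the data shown here, compound 1 and compound 3 report no result, so the series offers no measured step between related compounds to calibrate the next one.

The next compound to be read is compound 4 `CC[C@H](c1ccc(C(=O)O)c(Oc2cccc(Cl)c2)c1F)N1CCC[C@H](n2cc(C)c(=O)[nH]c2=O)C1`, which keeps the rest of compound 2 and changes one substituent: fluoro in place of methoxy on an aromatic carbon. In words, this is fluoro in place of methoxy on an aromatic carbon, ortho to a 3-chlorophenoxy group and meta to a carboxy group.

With a single number to go on, the expectation is tentative. Starting from compound 2 at 84 mL/min/kg, a modest move toward slower clearance is expected, and that move may well stay within the usual scatter of the measurement. The estimated step is a 1.4-fold lower number from compound 2 to compound 4 (0.15 log units; within the scatter). For compound 4 the estimated clearance is 60 mL/min/kg, with an expected range of 28 mL/min/kg to 115 mL/min/kg.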

Compound 4, clearance: 119 mL/min/kg
The estimate for compound 4 lay 2.0-fold (0.30 log units) below the measured number, outside the stated range (above it).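

In this assay, the series now has its first measured step between related compounds: replacing methoxy with fluoro on the aromatic carbon ortho to a 3-chlorophenoxy group and meta to a carboxy group gives a 1.4-fold higher number from compound 2 to compound 4 (0.15 log units; within the scatter). Compound 2 and compound 4 therefore cannot be told apart on this read-out, so this single exchange at this position, which removes a hydrogen-bond acceptor and one heavy atom, does not yield a measurable difference in clearance. Nothing available accounts for the size or direction of this step.

From the compounds shown here alone, whether the configuration as drawn matters in this assay remains open, as compound 1 reports no result and so gives no comparison with compound 4: the fact that compounds 1 and 4 differ only in the configuration as drawn Also open is whether a different group at this aromatic position, such as an amine, a nitrile or a longer ethoxy chain, would move clearance beyond the usual scatter.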